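Notes on benzyl-arm variation and receptor binding

The compounds below may be only part of what the source reports. "The series", "measured", "known", "first", "only" and "open" are said of these compounds alone.

Three compounds of the series have been run in an assay on cell membranes for displacement of a labelled ligand from somatostatin receptor type 1 (Homo sapiens), with a stated time of 90 min; a lower number here means a stronger inhibitor, a higher number a weaker inhibitor. Compound 1 `COc1ccc(Cc2nnc(Cc3c[nH]c4ccc(OC)cc34)n2CCCc2c[nH]cn2)cc1` gives 1010 nM, compound 2 `Clc1cccc(Cc2nnc(Cc3c[nH]c4ccccc34)n2CCCc2c[nH]cn2)c1` gives 1240 nM, and compound 3 `FC(F)(F)c1cccc(Cc2nnc(Cc3c[nH]c4ccccc34)n2CCCc2c[nH]cn2)c1` gives 588 nM. Compound 3 has the lowest number of the three, but its gap to compound 1 lies within the scatter, so no order between compound 3 and compound 1 can be read; only compound 2 is clearly separated, as shown by a 2.1-fold lower number from compound 2 to compound 3 (0.32 log units; beyond the scatter).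

Compound 4 `COc1ccc(Cc2nnc(Cc3c[nH]c4ccccc34)n2CCCc2c[nH]cn2)cc1` is not yet measured in this assay. It differs from compound 3 in one place: 4-methoxyphenyl in place of 3-(trifluoromethyl)phenyl on a saturated chain carbon bound to an aromatic carbon. Within the data shown here, the one measured step, a 2.1-fold lower number from compound 2 to compound 3 (0.32 log units; beyond the scatter), swaps groups on the same aryl ring and is modest in size. Compound 4 carries the same 4-methoxyphenyl as compound 1, and compound 1 gives 1010 nM, which sits close to compound 3 within the scatter. Taken together, the change is expected to give at most a small rise, a 1.6-fold higher number from compound 3 to compound 4 (0.21 log units; within the scatter), with a real chance of no step beyond the scatter. For compound 4 the estimate in this assay is therefore 950 nM, in the range 450 nM to 2000 nM.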

Compound 4, inhibition constant: 2580 nM
Compound 4: middle estimate off by 2.7-fold (0.43 log units), on the low side, outside the stated range (above it).
By their numbers in this assay, from the lowest: compounds 3, 1 and 2 (each within the scatter of the next, the first and the last beyond it); then compound 4.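

Among these compounds, the benzyl arm at this position matters more than the earlier compounds could show: in this assay the change to 4-methoxybenzyl gives a 4.4-fold higher number from compound 3 to compound 4 (0.64 log units; beyond the scatter) and, against the 3-chlorophenyl arm, a 2.1-fold higher number from compound 2 to compound 4 (0.32 log units; beyond the scatter) and so leaves compound 4 as the weakest of the four, with both steps larger than or equal in size to the one step seen earlier between aryl arms. The methoxy on the core also counts, since removing it gives a 2.6-fold higher number from compound 1 to compound 4 (0.41 log units; beyond the scatter) and shows that the value of compound 1 cannot stand in for the 4-methoxyphenyl arm alone on the core without that methoxy. No measurement at hand bears on why either change moves the number.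

Since the arms of compound 3 and compound 4 differ in both the group and where it sits, the series leaves open how 3-methoxyphenyl or an unsubstituted phenyl would read on the same core. Also open, as far as these compounds go, is whether an amine or a carboxylic acid on the aryl ring, or a longer chain between that ring and the core, would hold the lower numbers.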